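Tert-butyl for methyl in a cell toxicity test

The source may hold more compounds than are shown below. What is called first, only, known or untested is meant among the compounds shown, and "the series" means these compounds.

Compound 1 (`CC(C)OC(=O)COC(=O)c1ccc([N+](=O)[O-])o1`), compound 2 (`CCC(C)(C)NC(=O)COC(=O)c1ccc([N+](=O)[O-])o1`) and compound 3 (`CC(=O)COC(=O)c1ccc([N+](=O)[O-])o1`) share a core. In an ADME assay on HEK-293T cells (Homo sapiens) for cytotoxicity, read by MTT assay, with a stated time of 3 days (on this read-out lower numbers stand for higher toxicity in this test and higher numbers for lower toxicity in this test), compound 1 gives > 100000 nM as its result, a limit of the assay and not a number. Compound 2 gives > 100000 nM as its result, again a limit. Compound 3 gives > 100000 nM as its result, also a limit. The three are summed up by the limit of > 100000 nM in this assay, at which 3 of the 3 values shown sit, and so no number ranks compound 3 against the others.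

Compound 4 (`CC(C)(C)C(=O)COC(=O)c1ccc([N+](=O)[O-])o1`) has tert-butyl in place of methyl on a carbonyl carbon. Two measured steps changed the group at that same place, a step that the two limits leave unreadable from compound 1 to compound 3 and a step that the two limits leave unreadable from compound 2 to compound 3 and neither has a size that can be read. With no measured change to go on, no step beyond the scatter is expected in this assay and no direction can be given. The expected step is a number no higher from compound 3 to compound 4 (the limit leaves the size open) as an estimate only. Compound 4 is estimated at 100000 nM with an expected range from 40000 nM to 200000 nM in this test.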

Compound 4, half-maximal cytotoxic concentration: > 100000 nM
Compound 4 was reported as a limit; the forecaster's own chance of this, stated with the estimate: 85%; the middle value lies on the limit itself.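

For the compounds shown here, no step to compound 4 can be read from compound 1, compound 2 or compound 3, because each result is a limit and not a number: the limit of > 100000 nM in this assay, at which 4 of the 4 values shown sit. The compounds shown leave open how their toxicity ranks and whether the group on the carbonyl carbon affects it.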